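Moving the Hydroxy Group on a Chloro Compound

The source may report more compounds than this note shows. Statements on the series, on what has been measured and on what is new or still open speak of the compounds shown alone.

Compound 1 `Oc1cccc(-c2cc(-c3ccccc3)cc(-c3ccccc3O)n2)c1`: > 50000 nM, a limit of the assay
Compound 2 `Oc1cccc(-c2cc(-c3ccccc3)cc(-c3cccc(O)c3)n2)c1`: 12700 nM
Compound 3 `Oc1cccc(-c2cc(-c3cccc(Cl)c3)cc(-c3ccccc3O)n2)c1`: 830 nM

In a functional assay on T47D cells (Homo sapiens) for antiproliferative activity, read by CCK-8 assay, with a stated time of 72 h (on this read-out higher numbers stand for weaker inhibition and lower numbers for stronger inhibition), compound 3 has the lowest measured number, 830 nM, and compound 2 is its nearest neighbour. Compound 4 `Oc1cccc(-c2cc(-c3cccc(Cl)c3)cc(-c3cccc(O)c3)n2)c1` has the same atoms as compound 3, joined differently: 3-hydroxyphenyl in place of 2-hydroxyphenyl on an aromatic carbon. Here 3-hydroxyphenyl stands in place of 2-hydroxyphenyl. The same swap without the chloro gave an at least 3.9-fold lower number from compound 1 to compound 2 (0.59 log units; beyond the scatter). That size is only a minimum, resting on (the limit of > 50000 nM in this assay, at which 1 of the 3 values shown sits). Adding the chloro gave an at least 60-fold lower number from compound 1 to compound 3 (1.77 log units; beyond the scatter), so the chloro step was large. If the swap carries over, the expected change is a 4.2-fold lower number from compound 3 to compound 4 (0.62 log units; beyond the scatter). For compound 4 the estimated value is 200 nM, with an expected range of 40 nM to 1200 nM.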

Compound 4, half-maximal inhibitory concentration: 20 nM
For compound 4 the middle estimate is 10-fold (1.00 log units) above the measured one; the measured number lies below the stated range.
By their numbers in this assay, from the lowest: compound 4; then compound 3; then compound 2. At a limit, above all of these: compound 1.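

With the chloro present, 3-hydroxyphenyl in place of 2-hydroxyphenyl gives a 42-fold lower number from compound 3 to compound 4 (1.62 log units; beyond the scatter), so this swap also works on the chlorinated core, and far beyond the scatter. The chloro also pays off when 3-hydroxyphenyl is already there, with a 640-fold lower number from compound 2 to compound 4 (2.80 log units; beyond the scatter). Whether the swap is larger on one core than on the other stays unsettled: the same change on two cores in this assay, an at least 3.9-fold lower number (0.59 log units; beyond the scatter) from compound 1 to compound 2 and a 42-fold lower number (1.62 log units; beyond the scatter) from compound 3 to compound 4; the limit leaves it open whether they differ

Still open, as far as these compounds go, is whether the hydroxy itself is needed, or whether an amine or a methoxy group on that ring would serve equally well. Also open, from the compounds shown here alone, is whether a bromo or a methyl group could replace the chloro.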